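Replacing the Nitrile with Chlorine on the Aryl Urea

The compounds below may be only part of what the source reports. "The series", "measured", "known", "first", "only" and "open" are said of these compounds alone.

Going by the values given here, compound 2 `CC1(C)CN(NC(=O)Nc2cccc(C#N)c2)c2cc(Cl)ccc2O1` gives 1900 nM in a functional assay on thoracic aorta (Rattus norvegicus) (a higher number here means that more compound is needed for the effect, a lower number that less compound is needed), the only number so far in this small set. Compound 1 `CC1(C)CN(NC(=S)Nc2cccc(C#N)c2)c2cc(Cl)ccc2O1` reaches only a limit of the assay there, > 30000 nM, as recorded in the limit of > 30000 nM in this assay, at which 1 of the 2 values shown sits. Compound 3 `CC1(C)CN(NC(=O)Nc2cccc(Cl)c2)c2cc(Cl)ccc2O1` differs from compound 2 by chloro in place of cyano on an aromatic carbon. Among the compounds with values here, no measured step covers this change, so the expectation rests on compound 2 alone. The step is expected to be small, a 1.3-fold higher number from compound 2 to compound 3 (0.12 log units; within the scatter), with no clear direction beyond the usual scatter. Compound 3 is therefore estimated at 2500 nM, within a range from 600 nM to 10000 nM.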

Compound 3, half-maximal effective concentration: 9900 nM
The estimate for compound 3 lay 4.0-fold (0.60 log units) below the measured number; the measured number falls inside the stated range.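

In this assay, the change from 3-cyanophenyl to 3-chlorophenyl gives a 5.2-fold higher number from compound 2 to compound 3 (0.72 log units; beyond the scatter). Going by these compounds alone, this is the first measured step at this aromatic carbon, and it shows that the group there affects the read-out even with the urea kept in place. Here, cyano needs less compound than chloro.

Going by these compounds, whether a methoxy group, an amine or a carboxylic acid at the same carbon would need less compound than cyano remains open. Nothing shown accounts for the size or direction of this step.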